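Swapping a Chloro for a Methoxy on the Aryl Ring

The source may report more compounds than this note shows. Statements on the series, on what has been measured and on what is new or still open speak of the compounds shown alone.

Compound 3 `Cc1cc2nn(-c3ccc(Cl)cc3)c(C)c2c(=O)o1` gives the highest of the three numbers measured in a functional assay on the whole organism for inhibition, with Rattus norvegicus as the target, read by paw edema, with a stated time of 3 h, at a dose of 50 mg/kg (a lower number here means less inhibition, a higher number more inhibition at the dose given (going by the name of the read-out)), namely 56.6%. Its closest companion is compound 2 `Cc1ccc(-n2nc3cc(C)oc(=O)c3c2C)cc1`, which gives 54% in this assay; the two differ only by chloro in place of methyl on an aromatic carbon, and the step of a number 2.6 percentage points higher from compound 2 to compound 3 (within the scatter) is within the scatter. Compound 1 `COc1ccc(NNc2cc(C)oc(=O)c2C(C)=O)cc1`, built on a different core, gives 44.4% in this assay, a number beyond the scatter below compound 3.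

Compound 4 `COc1ccc(-n2nc3cc(C)oc(=O)c3c2C)cc1` is the next variation: methoxy in place of chloro on an aromatic carbon. Within the data shown here, no measured pair shows a methoxy replacing a chloro on this core, so nothing directly bears on the step. Among the measured compounds shown here, the one step measured on the shared core, the change from methyl to chloro, was small and within the scatter, which suggests a substituent swap at this ring position moves the number little. For the measured compounds named here, compound 1 carries a methoxy too, but its core differs, so its value shows only that a methoxy-bearing compound can sit lower.

On this basis, compound 4 is expected to land near compound 3, with the step of a number 4.6 percentage points lower from compound 3 to compound 4 (within the scatter) estimated to stay within the scatter. The estimate for compound 4 in this assay is 52%, with a range from 40% to 63%.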

Compound 4, a percentage reported as inhibition, in the whole organism at one dose (the size of the read-out at that dose, not a potency): 57.6%
The estimate for compound 4 lay 5.6 percentage points below the measured number; measured number inside the range.
By their numbers in this assay, from the lowest: compounds 1, 2, 3 and 4 (each within the scatter of the next, the first and the last beyond it).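

Methoxy in place of chloro on this aromatic carbon, para to a large group, gives in this assay a number 1 percentage points higher from compound 3 to compound 4 (within the scatter) and methoxy in place of methyl gives a number 3.6 percentage points higher from compound 2 to compound 4 (within the scatter). Together with the earlier step of a number 2.6 percentage points higher from compound 2 to compound 3 (within the scatter) this means that methyl, chloro and methoxy all lie within the scatter of one another on the shared core, so at this dose the position accepts a group of two heavy atoms with a hydrogen-bond acceptor as readily as the smaller groups. No measurement at hand explains why these three groups read alike.

As far as these compounds go, whether an amine, a carboxylic acid or a longer chain such as butoxy at this position would also stay within the scatter remains open. So does whether these three compounds would still read alike at other doses, since a single dose shows no potency.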